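Hydroxymethyl in Place of Phenyl Within a Series at the Limit

The source may hold more compounds than are shown below. What is called first, only, known or untested is meant among the compounds shown, and "the series" means these compounds.

Measured compounds:
- Compound 1, `CC1(C)CC(=O)C(C(=S)SCCO)=C(Nc2ccc(Cl)cc2Cl)C1`; in a functional assay on PBMC cells (Homo sapiens) for inhibition, read by thymidine incorporation, with a stated time of 72 h (on this read-out lower numbers stand for stronger inhibition and higher numbers for weaker inhibition), compound 1 gives only a limit, > 50 ug/mL.
- Compound 2, `CCCCCCCCCCCSC(=S)C1=C(Nc2ccc(Cl)cc2)CC(C)(C)CC1=O`; in this assay compound 2 gives only a limit, > 50 ug/mL.
- Compound 3, `CC1(C)CC(=O)C(C(=S)SCc2ccccc2)=C(Nc2ccc(Cl)cc2)C1`; in this assay compound 3 gives only a limit, > 50 ug/mL.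

Compound 3 thus stands at a limit rather than at a number, and every value shown sits at that same limit (the limit of > 50 ug/mL in this assay, at which 3 of the 3 values shown sit). Among the compounds with values here, the single measured step at the sulfur-bound carbon, a step that the two limits leave unreadable from compound 2 to compound 3, is therefore unreadable, since both of its ends are limits. Compound 4, `CC1(C)CC(=O)C(C(=S)SCCO)=C(Nc2ccc(Cl)cc2)C1`, differs from compound 3 in one place: hydroxymethyl in place of phenyl on a saturated chain carbon bound to a sulfur. Compound 1 already carries the (2-hydroxyethyl)sulfanyl group on a core differing elsewhere, and its value is a limit. Within the data shown here, no measured step gives a readable size, so no step beyond the scatter can be expected, and the most likely outcome is a further limit. Compound 4 is estimated at 80 ug/mL, within 30 ug/mL to 250 ug/mL. The step expected from this estimate is a step that the limit leaves unreadable from compound 3 to compound 4.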

Compound 4, half-maximal inhibitory concentration: 21 ug/mL
Beside the measured number, compound 4's estimate is 3.8-fold (0.58 log units) above it; the measured number lies below the stated range.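

In this assay, within the data shown here, hydroxymethyl in place of phenyl on a saturated chain carbon bound to a sulfur gives an at least 2.3-fold lower number from compound 3 to compound 4 (0.37 log units; beyond the scatter), the first step at this position that can be read and one that lies beyond the scatter. Compound 4 also stands apart from its other two neighbours, with an at least 2.3-fold lower number from compound 2 to compound 4 (0.37 log units; beyond the scatter) for hydroxy in place of nonyl and an at least 2.3-fold lower number from compound 1 to compound 4 (0.37 log units; beyond the scatter) for hydrogen in place of chloro on an aromatic carbon, so the change on the aromatic carbon matters as well. All three sizes remain lower bounds, as compound 4 alone carries a number: the limit of > 50 ug/mL in this assay, at which 3 of the 4 values shown sit.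

The step between the two limits at the sulfur-bound carbon still cannot be read. The compounds shown leave open whether an amine or a carboxylic acid in place of the hydroxy, or a longer chain carrying the hydroxy, would hold this number.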